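A few compounds are considered here, and "the series" means these few. Any claim that something is new, unique, unknown or untested is made for them only; others in the source may bear on it.

Compound 1 `O=S(=O)(/C=C/c1ccccc1)Cc1ccc(Nc2ncnc3ccccc23)cc1`: > 100000 nM
Compound 2 `O=S(=O)(/C=C/c1ccc(Cl)cc1)Cc1ccc(Nc2ncnc3ccccc23)cc1`: 77000 nM
Compound 3 `O=S(=O)(/C=C/c1ccc(O)cc1)Cc1ccc(Nc2ncnc3ccccc23)cc1`: 100000 nM

These results come from a functional assay on SW-620 cells (Homo sapiens); on this read-out lower numbers stand for stronger inhibition of growth and higher numbers for weaker inhibition of growth. The value of compound 1 is a limit of the assay, not a number. Only compound 2 and compound 3 have numbers, and these lie within the scatter of each other: a 1.3-fold higher number from compound 2 to compound 3 (0.11 log units; within the scatter).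

Compound 4 `O=S(=O)(/C=C/c1ccc(Cl)cc1)Cc1ccc(Nc2ncnc3ccc(Br)cc23)cc1` differs from compound 2 by one change: bromo in place of hydrogen on an aromatic carbon. No bromo change has been measured. The closest evidence is the swaps of groups on an aromatic carbon elsewhere in the molecule. One of these has a floor within the scatter: an at least 1.2-fold lower number from compound 1 to compound 2 (0.11 log units; that floor lies within the scatter). With both readable sizes this small, the expected change is no step beyond the scatter, and the expected step is a 1.2-fold lower number from compound 2 to compound 4 (0.07 log units; within the scatter). Compound 4 is estimated at 65000 nM, with an expected range of 25000 nM to 100000 nM.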

Compound 4, concentration for 50% growth inhibition: 45000 nM
The estimate for compound 4 lay 1.4-fold (0.16 log units) above the measured number; measured number inside the range.
By their numbers in this assay, from the lowest: compounds 4, 2 and 3 (each within the scatter of the next, the first and the last beyond it).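

This is the first change shown on the fused system of two rings; the earlier changes all sat on a different ring. In this assay, bromo in place of hydrogen there gives a 1.7-fold lower number from compound 2 to compound 4 (0.23 log units; within the scatter), so this carbon accepts a bromo with no step beyond the scatter, and no gain can be claimed. Compound 1 remains a limit of the assay, not a number: the limit of > 100000 nM in this assay, at which 1 of the 4 values shown sits.

As far as these compounds go, whether an amine or a methoxy group on this carbon would give a step beyond the scatter stays open. So does the effect of bromo on the other carbons of this ring.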